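From methoxy to chloro on the aromatic ring

This account rests on a few compounds, and the source may have more. Where it says the series, first, only, none or still open, it means among the compounds named here.

compound 1 `Clc1ccc(CCCN2CCC(COC(c3ccccc3)c3ccccc3)CC2)cc1`: 500 nM
compound 2 `COc1cccc(CCCN2CCC(COC(c3ccccc3)c3ccccc3)CC2)c1`: 1500 nM
compound 3 `COc1ccccc1CCCN1CCC(COC(c2ccccc2)c2ccccc2)CC1`: 2400 nM

In a functional assay on cells (T-cell line, Homo sapiens) for inhibition (a higher number here means a weaker inhibitor, a lower number a stronger inhibitor), compound 3 stands with compound 2 at the high-number end of this small set. The gap between them is a 1.6-fold higher number from compound 2 to compound 3 (0.20 log units; within the scatter), whereas compound 1 lies apart, with a 4.8-fold higher number from compound 1 to compound 3 (0.68 log units; beyond the scatter). Compound 4 `Clc1ccccc1CCCN1CCC(COC(c2ccccc2)c2ccccc2)CC1` has chloro in place of methoxy on an aromatic carbon. For the measured compounds named here, no measured pair makes this exact swap. Going by the values given here, compound 1 is the only measured chloro compound, but its group also sits elsewhere, and it shows a 3.0-fold higher number from compound 1 to compound 2 (0.48 log units; beyond the scatter). Only part of that difference is expected to carry over. The expected step is modest, toward a lower number: a 2.4-fold lower number from compound 3 to compound 4 (0.38 log units; beyond the scatter). For compound 4 the estimated value is 1000 nM, with an expected range of 450 nM to 2200 nM.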

Compound 4, half-maximal inhibitory concentration: 800 nM
For compound 4 the middle estimate is 1.3-fold (0.10 log units) above the measured one, and the stated range covers the measured number.
By their numbers in this assay, from the lowest: compounds 1, 4, 2 and 3 (each within the scatter of the next, the first and the last beyond it).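

In this assay, for the compounds shown here, the swap of methoxy for chloro, ortho to a large group, is the first change measured at a single position, and it gives a step beyond the scatter (a 3.0-fold lower number from compound 3 to compound 4 (0.48 log units; beyond the scatter)). The 2-chlorophenyl group also stays within the scatter of the 4-chlorophenyl group (a 1.6-fold higher number from compound 1 to compound 4 (0.20 log units; within the scatter)) and the 3-methoxyphenyl group (a 1.9-fold lower number from compound 2 to compound 4 (0.27 log units; within the scatter)). Nothing available explains these steps. From the compounds shown here alone, it remains open whether fluoro, methyl or an amine at this place would behave like chloro, and how 3-chlorophenyl would compare with 3-methoxyphenyl.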